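Cytotoxicity notes on an aryl exchange in the shared core

The source may report more compounds than this note shows. Statements on the series, on what has been measured and on what is new or still open speak of the compounds shown alone.

Measured so far in an ADME assay on HepG2 2.2.15 cells (Homo sapiens) for cytotoxicity, read by MTT assay, with stated times of 3 days and 7 days; a higher number here means that more compound is tolerated, a lower number that less compound is tolerated:
- compound 1 `Cc1cccc(-c2cc(C(=O)N3CCC(Cc4ccccc4)CC3)c3ccccc3n2)c1` gives > 20000 nM, which is a limit of the assay and not a number.
- compound 2 `O=C(c1cc(-c2ccsc2Cl)nc2ccccc12)N1CCC(Cc2ccccc2)CC1` gives > 20000 nM, likewise a limit of the assay.

Among the measured compounds shown here, compound 2 thus stands at the same limit as the only other value shown in this assay; both values sit at the limit of > 20000 nM in this assay, at which 2 of the 2 values shown sit, so no number exists for either. For the measured compounds named here, the single measured step, a step that the two limits leave unreadable from compound 1 to compound 2, is for that reason unreadable and tells nothing about direction or size.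

Compound 3 `O=C(c1cc(-c2cccc(Br)c2)nc2ccccc12)N1CCC(Cc2ccccc2)CC1` is not yet measured in this assay. It differs from compound 2 in one place: 3-bromophenyl in place of 2-chlorothiophen-3-yl on an aromatic carbon. Going by the values given here, the only step that bears on this position is the unreadable one above, in which a 3-methylphenyl group and a 2-chlorothiophen-3-yl group were both tolerated up to the limit. Nothing in the shown data argues for a step beyond the scatter in this assay. For compound 3 the expected step is a step that the limit leaves unreadable from compound 2 to compound 3, essentially none. Compound 3 is estimated at 30000 nM, with a range from 15000 nM to 80000 nM, and most probably will again be reported only as a limit.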

Compound 3, half-maximal cytotoxic concentration: > 20000 nM
Compound 3: no number, only a limit (the forecaster's own chance of this, stated with the estimate: 75%); the middle value lies beyond the limit too.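

Among compound 1, compound 2 and compound 3, no step can be read in this assay, since each value is a limit of the assay and not a number: the limit of > 20000 nM in this assay, at which 3 of the 3 values shown sit.

The compounds shown leave open how much of each compound is tolerated, and whether any aryl exchange at this position of the shared core changes that at all.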